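The source may report more compounds than this note shows. Statements on the series, on what has been measured and on what is new or still open speak of the compounds shown alone.

Measured compounds:
compound 1 `COc1ccccc1C(=O)Nc1ccc(Sc2nc3ccccc3s2)cc1` — > 100000 nM
compound 2 `O=C(Nc1ccc(Sc2nc3ccccc3s2)cc1)c1cc(Br)cc(Br)c1O` — 4700 nM

In an assay for inhibition of HSP60/HSP10 (Homo sapiens), with a stated time of 60 min (on this read-out higher numbers stand for weaker inhibition and lower numbers for stronger inhibition), compound 1 gives > 100000 nM, which is a limit of the assay. Among the measured compounds shown here, compound 2 gives 4700 nM, the only number in this assay. The value of compound 1 is a limit (the limit of > 100000 nM in this assay, at which 1 of the 2 values shown sits). The step between them is an at least 21-fold lower number from compound 1 to compound 2 (1.32 log units; beyond the scatter). Compound 3 `O=C(Nc1ccc(Sc2nc3ccccc3s2)cc1)c1cccc(Br)c1` carries 3-bromophenyl in place of 3,5-dibromo-2-hydroxyphenyl on a carbonyl carbon, removing the hydroxyl and one bromine that entered in that step. For the measured compounds named here, only the step from compound 1 to compound 2 bears on this change, and it was large, so a clear rise in this assay is expected, possibly back to the limit. Compound 3 is estimated at 30000 nM, range 8000 nM to 100000 nM. The expected step is a 6.4-fold higher number from compound 2 to compound 3 (0.81 log units; beyond the scatter).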

Compound 3, half-maximal inhibitory concentration: > 100000 nM
Compound 3: no number, only a limit; the forecaster's own chance of this, stated with the estimate: 35%; middle value at least 3.3-fold (0.52 log units) from the limit.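

Replacing 3,5-dibromo-2-hydroxyphenyl with 3-bromophenyl on a carbonyl carbon gives an at least 21-fold higher number from compound 2 to compound 3 (1.32 log units; beyond the scatter) in this assay, so a lone bromine does not keep the activity of compound 2. Compound 3 has only a limit, not a number, and compound 1 shares it: the limit of > 100000 nM in this assay, at which 2 of the 3 values shown sit. The step from compound 1 to compound 3 cannot be read.

On these data alone, the hydroxyl and the second bromine leave together here, so the share of each in the step stays open. As far as these compounds go, whether an amine or a carboxylic acid in place of the hydroxyl would give a measurable number is also open.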